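The compounds below may be only part of what the source reports. "The series", "measured", "known", "first", "only" and "open" are said of these compounds alone.

Compound 1 `COC(=O)[C@@]1(C)CCC=C2[C@@H]1CC[C@@H](C)[C@]2(C)Cc1c(C)[nH]c2ccc(Cl)cc12` and compound 2 `COC(=O)[C@@]1(C)CCC=C2[C@@H]1CC[C@@H](C)[C@]2(C)Cc1c(C)[nH]c2ccc(F)cc12` share one core. In a functional assay on HBL-100 cells (Homo sapiens) for inhibition, read by sulforhodamine B assay, with a stated time of 48 h (a lower number here means a stronger inhibitor of growth, a higher number a weaker inhibitor of growth), compound 1 gives 15000 nM, while compound 2 gives 14000 nM. The step between them, a 1.1-fold lower number from compound 1 to compound 2 (0.03 log units; within the scatter), goes with the change (fluoro in place of chloro on an aromatic carbon). Compound 3 `COC(=O)[C@@]1(C)CC[C@@H]2C3=C1CC[C@@H](C)[C@]3(C)C[C@@H]1c3cc(Cl)ccc3N[C@H]21` is built on a different core; the difference between the two cores is not broken down here. In this assay compound 3 gives 28000 nM, and its values and those of compound 1 and compound 2 lie within the scatter of each other. Compound 4 `COC(=O)[C@@]1(C)CC[C@@H]2C3=C1CC[C@@H](C)[C@]3(C)C[C@@H]1c3cc(F)ccc3N[C@H]21` has not yet been measured. It differs from compound 3 by fluoro in place of chloro on an aromatic carbon. This is the same kind of change as that from compound 1 to compound 2, but not the same: in compound 3 the aromatic ring is part of a fused or bridged system of five rings, whereas in compound 1 it is part of a fused or bridged system of two rings. The estimate rests on the value that compound 3 gives in this assay, 28000 nM. Since the earlier step of a 1.1-fold lower number from compound 1 to compound 2 (0.03 log units; within the scatter) lay within the scatter, he expects the step of a 1.1-fold lower number from compound 3 to compound 4 (0.03 log units; within the scatter) to be of about the same size. His estimate for compound 4 in this assay is 26000 nM, between 13000 nM and 52000 nM.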

Compound 4, concentration for 50% growth inhibition: 18000 nM
Compound 4: the middle estimate sits 1.4-fold (0.16 log units) above what was measured; low and high end bracket the measured number.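

In this assay, fluoro in place of chloro on the second core gives a 1.6-fold lower number from compound 3 to compound 4 (0.19 log units; within the scatter), a step that stays within the scatter, as the earlier one did. Set side by side, the two steps cannot be told apart: the same change on two cores in this assay, a 1.1-fold lower number (0.03 log units; within the scatter) from compound 1 to compound 2 and a 1.6-fold lower number (0.19 log units; within the scatter) from compound 3 to compound 4, 1.5-fold (0.16 log units) apart, within the scatter of two such steps. This shows that, for this one change in this one cell line, moving from the core of compound 1 to the core of compound 3 brought no readable difference; but neither step rises above the scatter, so it shows only that swapping these two halogens does little on either core, not that a larger step would carry across in the same way.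

The compounds shown leave open what other groups on this aromatic carbon would do, for instance a methoxy group, a nitrile or an amine, since chloro and fluoro are the only groups seen there. They also leave open whether a carboxylic acid or an amide in place of the methyl ester would shift these numbers on either core.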